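This account rests on a few compounds, and the source may have more. Where it says the series, first, only, none or still open, it means among the compounds named here.

Of the compounds shown here, three built on one shared core have been tested in a functional assay on RXF 393 cells (Homo sapiens) for inhibition; a lower number here means a stronger inhibitor of growth, a higher number a weaker inhibitor of growth. Compound 1 `O=C(/C=C/c1cccc(O)c1)c1cccc(-n2cc(-c3ccccc3)[nH]c2=O)c1` gives 1890 nM. Compound 2 `O=C(/C=C/c1cccc(O)c1)c1cccc(-n2cc(-c3ccc(Cl)cc3)[nH]c2=O)c1` carries a chloro in place of hydrogen on an aromatic carbon, and in this assay compound 2 gives 1510 nM; the step of a 1.3-fold lower number from compound 1 to compound 2 (0.10 log units; within the scatter) shows that this addition barely moves the number. Compound 3 `COc1cc(/C=C/C(=O)c2cccc(-n3cc(-c4ccccc4)[nH]c3=O)c2)cc(OC)c1OC` differs from compound 1 at another part of the molecule, and in this assay compound 3 gives 1710 nM. On these numbers compound 3 stands within the scatter of both compound 1 and compound 2, so none of the three can be called stronger or weaker than the others.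

Compound 4 `COc1ccc(-c2cn(-c3cccc(C(=O)/C=C/c4cc(OC)c(OC)c(OC)c4)c3)c(=O)[nH]2)cc1` has not yet been measured. It differs from compound 3 by methoxy in place of hydrogen on an aromatic carbon. For the measured compounds named here, the only measured step that bears on this is the one from compound 1 to compound 2, where a chloro entered the same ring at a place para to a large group and gave a change within the scatter. A methoxy is a different group from a chloro, but with this single comparison as a guide, the expected step of a 1.1-fold lower number from compound 3 to compound 4 (0.03 log units; within the scatter) is small and in no firm direction. Compound 4 is therefore estimated to give 1600 nM, with a likely range from 800 nM to 3500 nM.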

Compound 4, concentration for 50% growth inhibition: 1920 nM
Compound 4: middle estimate off by 1.2-fold (0.08 log units), on the low side; the range from low to high includes it.
By their numbers in this assay, from the lowest: compounds 2, 3, 1 and 4 (each within the scatter of the next).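

In this assay, methoxy in place of hydrogen, para to a large group, gives the step of a 1.1-fold higher number from compound 3 to compound 4 (0.05 log units; within the scatter), so compound 4 cannot be told apart from compound 3. Until now, only chloro had been seen at this place, on the core of compound 1, in the step of a 1.3-fold lower number from compound 1 to compound 2 (0.10 log units; within the scatter); a second and different group, on the core of compound 3, now also gives a step within the scatter, so this small insensitivity is seen for two groups on two versions of the molecule, though still only in these two pairs. No separate measurement is available that could explain this result.

On these data alone, whether an amine, a carboxylic acid or a longer chain such as butoxy at this same place would give a step beyond the scatter remains open, as the two groups seen here say nothing about those. Also open, as far as these compounds go, is whether the same picture would hold in any other cell line, as all four numbers come from this one assay.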